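A few compounds are considered here, and "the series" means these few. Any claim that something is new, unique, unknown or untested is made for them only; others in the source may bear on it.

Compound 2 `Cc1cc(C(F)(F)F)cnc1CCCC(=O)N1CCc2c(Cl)c(O)c(O)c(Cl)c2C1` gives 67% in a functional assay (Homo sapiens), tested at 1 uM; a higher number here means a weaker effect of the compound at the concentration tested, a lower number a stronger effect. Compound 1 `O=C(CCCc1ccc(C(F)(F)F)cn1)N1CCc2c(Cl)c(O)c(O)c(Cl)c2C1` gives 72% in this assay, and the step of a number 5 percentage points lower from compound 1 to compound 2 (within the scatter) places the two numbers within the scatter of each other. Compound 3 `O=C(CCCc1ncc(C(F)(F)F)cc1-c1ccccc1)N1CCc2c(Cl)c(O)c(O)c(Cl)c2C1` differs from compound 2 by phenyl in place of methyl on an aromatic carbon. Going by the values given here, the one measured step, methyl in place of hydrogen on an aromatic carbon, was within the scatter; no measured step concerns a phenyl entering on an aromatic carbon, so the basis for expectation is thin. A step of a number 2 percentage points lower from compound 2 to compound 3 (within the scatter) of no size beyond the scatter is expected, with wide uncertainty. Compound 3 is therefore estimated at 65%, with a range from 45% to 85%.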

Compound 3, a percentage reported as activity, at one concentration (the size of the read-out at that concentration, not a potency): 90%
Beside the measured number, compound 3's estimate is 25 percentage points below it, outside the stated range (above it).
By their numbers in this assay, from the lowest: compounds 2 and 1 (each within the scatter of the next); then compound 3.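

On the aromatic carbon ortho to a large group, the series is not indifferent to what is placed there: methyl made no change beyond the scatter in this assay, whereas phenyl brings a number 23 percentage points higher from compound 2 to compound 3 (beyond the scatter) and a number 18 percentage points higher from compound 1 to compound 3 (beyond the scatter), a weaker effect at the concentration tested. Going by these compounds alone, this is the first step that lies beyond the scatter. Nothing available accounts for this shift.

On these data alone, whether a fluorine, a methoxy group or a benzyl group at this position would behave like methyl or like phenyl remains open. Also open, as far as these compounds go, is whether a pyridyl ring in place of the phenyl would give the same weaker effect.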